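A few compounds are considered here, and "the series" means these few. Any claim that something is new, unique, unknown or untested is made for them only; others in the source may bear on it.

Measured compounds:

Compound 1 `N#Cc1cnc(NCc2ccccc2C(F)(F)F)cc1N[C@H]1CC[C@@H](O)CC1` gives 140 nM in an assay on isolated protein for inhibition of protein kinase C theta type (Homo sapiens), read by TR-FRET, with a stated time of 2 h; on this read-out higher numbers stand for weaker inhibition and lower numbers for stronger inhibition.

Compound 2 `N#Cc1cnc(NCc2ccccc2C(F)(F)F)cc1N[C@H]1CC[C@H](O)CC1` gives 4000 nM in this assay.

Compound 2 stands at the highest of the two numbers: the step of a 29-fold higher number from compound 1 to compound 2 (1.46 log units; beyond the scatter) shows it far behind compound 1, and the only difference between the two is the fact that compounds 1 and 2 differ only in the configuration as drawn, the two rings carrying the same atoms in mirror-image arrangement.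

Compound 3 `N#Cc1cnc(NCc2ccccc2C(F)(F)F)cc1N[C@H]1C[C@@H](C(N)=O)C1` is not yet measured. Compared with compound 2 it carries 3-carbamoylcyclobutyl in place of 4-hydroxycyclohexyl on a nitrogen on an aromatic ring, so the six-membered ring shrinks to a four-membered one and the hydroxyl is replaced by a carbamoyl group, while the count of hydrogen-bond donors and acceptors stays the same.

For the measured compounds named here, no measured step covers this kind of exchange; the single step in hand concerns configuration only, and it was large. The expectation for compound 3 is therefore loosely held: a step of a 2.7-fold lower number from compound 2 to compound 3 (0.43 log units; beyond the scatter) is expected, with wide uncertainty in either direction. Compound 3 is estimated at 1500 nM in this assay, with a range from 150 nM to 15000 nM.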

Compound 3, half-maximal inhibitory concentration: 150 nM
For compound 3 the middle estimate is 10-fold (1.00 log units) above the measured one; low and high end bracket the measured number.
By their numbers in this assay, from the lowest: compounds 1 and 3 (each within the scatter of the next); then compound 2.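

The nitrogen-linked position accepts more than one substituent: in this assay, exchanging the 4-hydroxycyclohexyl of the weaker isomer for 3-carbamoylcyclobutyl gives a 27-fold lower number from compound 2 to compound 3 (1.43 log units; beyond the scatter). Set against the stronger isomer, the same exchange gives a 1.1-fold higher number from compound 1 to compound 3 (0.03 log units; within the scatter), so a smaller ring carrying a carbamoyl group in place of the hydroxyl reaches the same level as the better cyclohexyl compound. The high number of compound 2 therefore says nothing against this position as a whole, and it goes with the arrangement of the 4-hydroxycyclohexyl rather than with its atoms: the fact that compounds 1 and 2 differ only in the configuration as drawn.

The ring size and the end group change together in this exchange, so the compounds shown cannot tell which of the two accounts for the result, and how the opposite configuration of the 3-carbamoylcyclobutyl would read remains open. As far as these compounds go, it also remains open whether a carboxylic acid or an amine in place of the carbamoyl on the same four-membered ring would hold the number seen for compound 3.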